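This account rests on a few compounds, and the source may have more. Where it says the series, first, only, none or still open, it means among the compounds named here.

Measured so far in a physicochemical assay for solubility, read by spectrophotometry, measured as kinetic solubility, at pH 8, tested at 500 uM; a higher number here means a more soluble compound, a lower number a less soluble compound:
- compound 1 `Cn1ccc2ccc(-c3cc(Nc4ccccc4S(N)(=O)=O)cc4nccnc34)cc21`: 6 ug/mL
- compound 2 `CN(C)S(=O)(=O)c1ccccc1Nc1cc(-c2ccc3ccn(C)c3c2)c2nccnc2c1`: 2 ug/mL
- compound 3 `Cn1ccc2ccc(-c3cc(Nc4ccccc4S(=O)(=O)Nc4cncnc4)cc4nccnc34)cc21`: 254 ug/mL

Compound 1 stands second highest of the three. Next is compound 4 `Cn1ccc2ccc(-c3cc(Nc4ccccc4S(=O)(=O)N4CCOCC4)cc4nccnc34)cc21`, with morpholin-4-yl in place of amino on a sulfonyl sulfur. Within the data shown here, the nearest precedent is dimethylamino in place of amino at that sulfur, a modest change: a 3.0-fold lower number from compound 1 to compound 2 (0.48 log units; beyond the scatter). The large 42-fold higher number from compound 1 to compound 3 (1.63 log units; beyond the scatter) comes with pyrimidin-5-yl in place of hydrogen on a sulfonamide nitrogen, and compound 4 carries no such group, so it bears less. A small downward step is therefore expected in this assay, one that may not clear the scatter: a 2.0-fold lower number from compound 1 to compound 4 (0.30 log units; within the scatter). For compound 4 the estimated value is 3 ug/mL, with an expected range of 1 ug/mL to 10 ug/mL.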

Compound 4, solubility: 5 ug/mL
Compound 4: middle estimate off by 1.7-fold (0.22 log units), on the low side; measured number inside the range.
By their numbers in this assay, from the lowest: compound 2; then compounds 4 and 1 (each within the scatter of the next); then compound 3.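

In this assay, morpholin-4-yl on the sulfonyl sulfur is not separable from amino: a 1.2-fold lower number from compound 1 to compound 4 (0.08 log units; within the scatter). Dimethylamino and morpholin-4-yl at this sulfur do not read alike, with a 2.5-fold higher number from compound 2 to compound 4 (0.40 log units; beyond the scatter), so the two replacements of amino need not share an outcome. Morpholin-4-yl does not reproduce what (pyrimidin-5-yl)amino gives, with a 51-fold lower number from compound 3 to compound 4 (1.71 log units; beyond the scatter), which leaves compound 3 alone at the top of these four.

No measurement at hand explains these differences. As far as these compounds go, whether a phenylamino group or a piperazin-1-yl group on this sulfur would approach compound 3 remains open.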